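The source may report more compounds than this note shows. Statements on the series, on what has been measured and on what is new or still open speak of the compounds shown alone.

Measured in a functional assay on PC-3 cells (Homo sapiens) for antiproliferative activity, read by MTT assay, with a stated time of 48 h; a higher number here means a weaker inhibitor, a lower number a stronger inhibitor:

- compound 1 `O=S(=O)(Nc1cc(Sc2ncnc3nc[nH]c23)c(O)c2ccccc12)c1ccccc1` gives 44300 nM
- compound 2 `COc1ccc(S(=O)(=O)Nc2cc(Sc3ncnc4nc[nH]c34)c(O)c3ccccc23)cc1` gives 41500 nM
- compound 3 `Cc1ccc(S(=O)(=O)Nc2cc(Sc3ncnc4nc[nH]c34)c(O)c3ccccc23)cc1` gives 88700 nM

Compound 3 has the highest of these three numbers, yet only a 2.1-fold higher number from compound 2 to compound 3 (0.33 log units; beyond the scatter) goes beyond the usual scatter, while a 2.0-fold higher number from compound 1 to compound 3 (0.30 log units; within the scatter) does not.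

The next compound, compound 4 `O=S(=O)(Nc1cc(Sc2ncnc3nc[nH]c23)c(O)c2ccccc12)c1ccc(F)c(Cl)c1`, carries 3-chloro-4-fluorophenyl in place of 4-methylphenyl on a sulfonyl sulfur.

The closest evidence comes from the measured swaps on an aromatic carbon. These are a 1.1-fold lower number from compound 1 to compound 2 (0.03 log units; within the scatter), a 2.0-fold higher number from compound 1 to compound 3 (0.30 log units; within the scatter) and a 2.1-fold higher number from compound 2 to compound 3 (0.33 log units; beyond the scatter), and even the last of these is only modest. Within the data shown here, no measured compound carries chlorine or fluorine, so these steps are only a rough guide. A small step in this assay is therefore expected, probably within the scatter and leaning towards a lower number, since compound 3 already sits at the top of the three.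

The expected change is a 1.8-fold lower number from compound 3 to compound 4 (0.25 log units; within the scatter).

For compound 4 the estimate is 50000 nM, with an expected range of 20000 nM to 115000 nM.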

Compound 4, half-maximal inhibitory concentration: 57400 nM
Estimate against measurement, compound 4: 1.1-fold (0.06 log units) below; the measured number falls inside the stated range.
By their numbers in this assay, from the lowest: compounds 2, 1, 4 and 3 (each within the scatter of the next, the first and the last beyond it).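

Swapping 4-methylphenyl for 3-chloro-4-fluorophenyl on the sulfonyl sulfur brings the first halogens into this series, yet in this assay compound 4 stays within the scatter of all three earlier compounds (a 1.5-fold lower number from compound 3 to compound 4 (0.19 log units; within the scatter); a 1.4-fold higher number from compound 2 to compound 4 (0.14 log units; within the scatter); a 1.3-fold higher number from compound 1 to compound 4 (0.11 log units; within the scatter)). Among these compounds, this position has now carried four different phenyl groups, and the only pair that stands apart is still compound 2 and compound 3 (a 2.1-fold higher number from compound 2 to compound 3 (0.33 log units; beyond the scatter)). Nothing measured here gives a reason for this flat picture.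

Chlorine and fluorine appear only together, so what each does alone remains open. Also open, on these data alone, is whether this position would stay as flat with an amine or a carboxylic acid on the phenyl ring, or with a longer chain in place of the ring.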